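The source may hold more compounds than are shown below. What is called first, only, known or untested is meant among the compounds shown, and "the series" means these compounds.

Measured so far in a functional assay on DU-145 cells (Homo sapiens) for inhibition, read by trypan blue exclusion, with a stated time of 72 h; a higher number here means a weaker inhibitor, a lower number a stronger inhibitor:
- compound 1 `Cn1ccc2cc(Nc3ncc4cc(S(=O)(=O)c5ccc(F)cc5F)c(=O)n(C)c4n3)ccc21` gives 750 nM
- compound 2 `COC(=O)Cn1ccc2cc(Nc3ncc4cc(S(=O)(=O)c5ccc(F)cc5F)c(=O)n(C)c4n3)ccc21` gives 5000 nM
- compound 3 `Cn1ccc2cc(Nc3ncc4cc(S(=O)(=O)c5ccc(Cl)cc5Cl)c(=O)n(C)c4n3)ccc21` gives 750 nM

Compound 1 stands level with compound 3 at the digits shown, the two together the lowest numbers of the three; the step of no change at the digits printed from compound 1 to compound 3 (within the scatter) lies within the scatter. Compound 2 sits furthest away, with a 6.7-fold higher number from compound 1 to compound 2 (0.82 log units; beyond the scatter).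

Compound 4 `Cn1c(=O)c(S(=O)(=O)c2ccc(F)cc2F)cc2cnc(Nc3ccc4c(c3)C(=O)C(=O)N4)nc21` is the next compound to be run in this assay. Against compound 1 it differs as follows: a group of 11 heavy atoms (8 carbon, 1 nitrogen, 2 oxygen; one five-membered non-aromatic ring with 1 hetero atom, one six-membered aromatic ring of carbon only) in place of a group of 10 heavy atoms (9 carbon, 1 nitrogen; one five-membered aromatic ring with 1 hetero atom, one six-membered aromatic ring of carbon only), on a nitrogen on an aromatic ring

Neither measured step touches this part of the molecule. The step from compound 1 to compound 3 changes only the ring on the sulfonyl sulfur and is flat. The step from compound 1 to compound 2 adds a methoxycarbonyl on the saturated chain carbon bound to the aromatic nitrogen of the same group and costs a modest amount; it is the only hint that this end of compound 1 is sensitive, and the change in compound 4 is far larger, exchanging the whole group including its aromatic five-membered ring and its methylated nitrogen. The expectation for compound 4 is therefore a weaker result, with a step of about a 3.3-fold higher number from compound 1 to compound 4 (0.52 log units; beyond the scatter), and wide uncertainty. The estimate for compound 4 in this assay is 2500 nM, with a range from 600 nM to 10000 nM.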

Compound 4, half-maximal inhibitory concentration: 75000 nM
The estimate for compound 4 lay 30-fold (1.48 log units) below the measured number; the whole stated range lies below it.
By their numbers in this assay, from the lowest: compounds 1 and 3 (each within the scatter of the next); then compound 2; then compound 4.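

In this assay, replacing the 1-methyl-1H-indol-5-yl group with the group that has a five-membered non-aromatic ring gives a 100-fold higher number from compound 1 to compound 4 (2.00 log units; beyond the scatter), so this position on a nitrogen on an aromatic ring does not accept every bicyclic group of similar size. Among these compounds, the shift is far greater than the one earlier change at this end, a 6.7-fold higher number from compound 1 to compound 2 (0.82 log units; beyond the scatter), and stands in sharp contrast to the exchange on the sulfonyl sulfur, no change at the digits printed from compound 1 to compound 3 (within the scatter), making this group the more sensitive of the two sites varied so far. Nothing measured here accounts for the size of this shift.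

Among the compounds shown here, the single step changes several things at once: the five-membered ring is no longer aromatic, two double bonds outside aromatic rings appear, and the hydrogen-bond donor count rises from none to one, so the contribution of each remains unresolved. Also open, on these data alone, is how a plain phenyl, or a phenyl carrying an amine or a carboxylic acid, would behave at this position on the same core in this assay.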